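A few compounds are considered here, and "the series" means these few. Any claim that something is new, unique, unknown or untested is made for them only; others in the source may bear on it.

Measured so far in a functional assay on HeLa S3 cells (Homo sapiens) for cytotoxicity, read by XTT assay, with a stated time of 3 days; on this read-out lower numbers stand for stronger inhibition and higher numbers for weaker inhibition:
compound 1 `OC[C@H]1O[C@@H](n2cc(F)c3c(-c4ccccc4)ncnc32)[C@H](O)[C@@H]1O` gives 2600 nM
compound 2 `OC[C@H]1O[C@@H](n2cc(Cl)c3c(-c4ccccc4)ncnc32)[C@H](O)[C@@H]1O` gives 420 nM

Among the measured compounds shown here, compound 2 holds the lower of the two numbers, with compound 1 as its only neighbour. Compound 3 `OC[C@H]1O[C@@H](n2cc(Cl)c3c(-c4cccs4)ncnc32)[C@H](O)[C@@H]1O` keeps the chloro group but has thiophen-2-yl in place of phenyl on an aromatic carbon. For the measured compounds named here, the only measured step, a 6.2-fold lower number from compound 1 to compound 2 (0.79 log units; beyond the scatter), is a modest one, swapped fluoro for chloro and left the phenyl untouched. It shows that a small swap can matter, but it gives no firm direction here. A modest step is expected, leaning cautiously downward: a 3.5-fold lower number from compound 2 to compound 3 (0.54 log units; beyond the scatter). The estimated value for compound 3 is 120 nM (range 20 nM to 600 nM).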

Compound 3, half-maximal inhibitory concentration: 28200 nM
Beside the measured number, compound 3's estimate is 240-fold (2.37 log units) below it; measured number outside the range, above it.
By their numbers in this assay, from the lowest: compound 2; then compound 1; then compound 3.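

In this assay, the group on this aromatic carbon, next to the ring nitrogen, turns out to matter greatly: thiophen-2-yl in place of phenyl gives a 67-fold higher number from compound 2 to compound 3 (1.83 log units; beyond the scatter) with the chloro group unchanged. This large step shows that one aromatic ring cannot simply be traded for another here, at least for this pair. Nothing measured here explains the loss.

Going by these compounds, whether a pyridyl ring or thiophen-3-yl would behave more like phenyl remains open. So does whether a methyl group or an amine could take this place.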